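Double-bond geometry and ring configuration in compound 4

The compounds below may be only part of what the source reports. "The series", "measured", "known", "first", "only" and "open" are said of these compounds alone.

Measured in an ADME assay on HFF cells (Homo sapiens) for cytotoxicity, read by neutral red uptake; a lower number here means that less compound is tolerated, a higher number that more compound is tolerated:
- compound 1 `Nc1nc2c(ncn2/C=C2\C[C@@H]2[C@@H](O)CO)c(=O)[nH]1`: > 300000 nM, a limit
- compound 2 `Nc1ncnc2c1ncn2/C=C1\C[C@H]1[C@H](O)CO`: 194000 nM
- compound 3 `Nc1ncnc2c1ncn2/C=C1\C[C@@H]1[C@H](O)CO`: > 300000 nM, a limit

Compound 1 stands at > 300000 nM, which is a limit and not a number. This is the limit of > 300000 nM in this assay, at which 2 of the 3 values shown sit, so the tolerated concentration of compound 1 is not known exactly.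

Compound 4 `Nc1nc2c(ncn2/C=C2/C[C@H]2[C@@H](O)CO)c(=O)[nH]1` is related to compound 1 as follows: the two compounds have the same atoms and bonds and differ only in configuration as drawn: 2 of 3 stereo elements differ; a stereocentre at a saturated ring carbon is drawn S in compound 1 and R in compound 4; a double bond is drawn E in compound 1 and Z in compound 4.

Going by the values given here, the only measured step bearing on this is an at least 1.5-fold higher number from compound 2 to compound 3 (0.18 log units; that floor lies within the scatter). It is informative because of the fact that compounds 2 and 3 differ only in the configuration as drawn, and it involves a stereocentre at a saturated ring carbon, though on a different core from that of compound 1. Among the compounds with values here, no measured step covers a change at the double bond.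

On the evidence of compound 2 and compound 3, with an at least 1.5-fold higher number from compound 2 to compound 3 (0.18 log units; that floor lies within the scatter), no change beyond the scatter is expected in this assay. The expected step is an at least 1.0-fold lower number from compound 1 to compound 4 (0.02 log units; that floor lies within the scatter). Compound 4 is estimated at 280000 nM, with an expected range from 130000 nM to 450000 nM.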

Compound 4, half-maximal cytotoxic concentration: 299000 nM
Estimate against measurement, compound 4: 1.1-fold (0.03 log units) below, and the stated range covers the measured number.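

In this assay, going by these compounds alone, compound 4 gives 299000 nM, the only value shown for a compound with the double bond drawn Z, and so the first sign that this geometry, together with the ring stereocentre drawn R, still leaves a high concentration tolerated. The double change gives a number no higher from compound 1 to compound 4 (the limit leaves the size open), so the two stereo elements cannot be weighed against each other here. Compound 1 gives > 300000 nM, which is a limit, and the size of the step stays unreadable for this reason: the limit of > 300000 nM in this assay, at which 2 of the 4 values shown sit.

As far as these compounds go, what the double bond and the ring stereocentre each do alone stays open, as both change together in this pair. Also open, from the compounds shown here alone, is how a carboxylic acid in place of the terminal hydroxyl group would read in this assay.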